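The source may report more compounds than this note shows. Statements on the series, on what has been measured and on what is new or still open speak of the compounds shown alone.

Measured so far in an assay for binding affinity to Neuropeptide Y receptor type 1 (Homo sapiens), read by radioligand binding; a higher number here means a weaker inhibitor, a lower number a stronger inhibitor:
- compound 1 `Nc1cc(S(=O)(=O)c2ccccc2)c([N+](=O)[O-])c2cccnc12`: 297 nM
- compound 2 `Nc1ccc([S+]([O-])c2cc(N)c3ncccc3c2[N+](=O)[O-])cc1`: 1250 nM
- compound 3 `Nc1ccc(S(=O)(=O)c2cc(N)c3ncccc3c2N)cc1`: reported only as the assay limit, > 10000 nM

Compound 1 holds the lowest of the two numbers; compound 2 sits a good way higher, beyond the scatter. For compound 3 only the limit is known (the limit of > 10000 nM in this assay, at which 1 of the 3 values shown sits).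

Next comes compound 4 `Nc1cc(S(=O)(=O)c2ccccc2Br)c([N+](=O)[O-])c2cccnc12`, which differs from compound 1 by bromo in place of hydrogen on an aromatic carbon. Among the compounds with values here, no comparable step has been measured, so the expected step from compound 1 to compound 4 is a 1.5-fold higher number from compound 1 to compound 4 (0.18 log units; within the scatter), taken as small and most likely within the scatter, with a lean toward a weaker value. Compound 4 is therefore estimated at 450 nM, expected between 120 nM and 1800 nM.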

Compound 4, inhibition constant: 234 nM
Estimate against measurement, compound 4: 1.9-fold (0.28 log units) above; the measured number falls inside the stated range.
By their numbers in this assay, from the lowest: compounds 4 and 1 (each within the scatter of the next); then compound 2. At a limit, above all of these: compound 3.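

In this assay, going from phenyl to 2-bromophenyl gives a 1.3-fold lower number from compound 1 to compound 4 (0.10 log units; within the scatter), so this aromatic carbon accepts a bromo without a step beyond the scatter. Within the data shown here, this is the first comparison that differs in one place only. Nothing measured here gives a reason for this step. On these data alone, whether a methoxy, an amine or a carboxylic acid on this same carbon would also hold the number stays open. So does the outcome for a bromo elsewhere on this ring.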